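The source may report more compounds than this note shows. Statements on the series, on what has been measured and on what is new or still open speak of the compounds shown alone.

Compound 1 `N#CC1=C(N)Oc2c(c3nc4ccccc4nc3c3ccccc23)C12C(=O)N(Cc1cnnn1-c1ccc(Br)cc1)c1ccccc12` gives 36600 nM in a functional assay on MCF7 cells (Homo sapiens) for antiproliferative activity, read by MTT assay, with a stated time of 48 h; a higher number here means a weaker inhibitor, a lower number a stronger inhibitor.
Compound 2 `CCc1ccccc1-n1nncc1CN1C(=O)C2(C(C#N)=C(N)Oc3c(N)cc4nc5ccccc5nc4c32)c2ccccc21` gives 24600 nM in this assay.

Among the compounds with values here, of these two numbers, the one for compound 2 is the lower, but its gap to compound 1 lies within the scatter of repeated measurements, so the two compounds are not truly told apart. Compound 3 `CCc1cccc(C)c1-n1nncc1CN1C(=O)C2(C(C#N)=C(N)Oc3c(N)cc4nc5ccccc5nc4c32)c2ccccc21` differs from compound 2 by methyl in place of hydrogen on an aromatic carbon. Within the data shown here, no measured pair shows a change of this kind, so nothing here tells how large it might be. The step of a 1.2-fold lower number from compound 2 to compound 3 (0.09 log units; within the scatter) is expected to stay within the scatter. Compound 3 is therefore estimated at 20000 nM, with a range from 8000 nM to 50000 nM.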

Compound 3, half-maximal inhibitory concentration: > 50000 nM
Compound 3: a limit, no number (the forecaster's own chance of this, stated with the estimate: 5%); middle value at least 2.5-fold (0.39 log units) away from the limit.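

In this assay, the change from 2-ethylphenyl to 2-ethyl-6-methylphenyl gives an at least 2.0-fold higher number from compound 2 to compound 3 (0.30 log units; that floor lies within the scatter). Compound 3 carries a limit of the assay, not a number: the limit of > 50000 nM in this assay, at which 1 of the 3 values shown sits. From the compounds shown here alone, the true size of this step therefore stays unknown and its floor does not separate the two compounds, but this methyl on an aromatic carbon, ortho to a large group, brings no visible gain in strength.

Going by these compounds, whether an amine or a methoxy group on the same carbon would read differently stays open. So does how the methyl would read without the ethyl group.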